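The compounds below may be only part of what the source reports. "The series", "measured", "known", "first", "only" and "open" are said of these compounds alone.

Compound 2 `O=C(c1ccc2c(c1)OCCO2)N1N=C(c2ccccc2)CC1c1cccc(F)c1` stands at the low end of the two numbers recorded so far: in a functional assay on WM 266-4 cells (Homo sapiens) for inhibition, read by MTT assay, with a stated time of 24 h (a higher number here means a weaker inhibitor of growth, a lower number a stronger inhibitor of growth), compound 2 gives 1840 nM. Among the measured compounds shown here, its only neighbour, compound 1 `O=C(c1ccc2c(c1)OCCO2)N1N=C(c2ccccc2)CC1c1ccccc1F`, gives 2500 nM in this assay, and the move a 1.4-fold lower number from compound 1 to compound 2 (0.13 log units; within the scatter) shows that shifting the fluorine on that ring made no real difference. Compound 3 `O=C(c1ccc2c(c1)OCCO2)N1N=C(c2ccccc2)CC1c1ccccc1` is not yet measured; it differs from compound 2 by hydrogen in place of fluoro on an aromatic carbon. For the measured compounds named here, since the one relevant step stayed within the scatter, the expected change a 1.2-fold higher number from compound 2 to compound 3 (0.08 log units; within the scatter) is none beyond the scatter. Compound 3 is therefore estimated at 2200 nM, expected to lie between 900 nM and 5500 nM.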

Compound 3, concentration for 50% growth inhibition: 1370 nM
Estimate against measurement, compound 3: 1.6-fold (0.21 log units) above; the range from low to high includes it.
By their numbers in this assay, from the lowest: compounds 3, 2 and 1 (each within the scatter of the next).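

Taking the fluorine off altogether, rather than moving it, also stays within the scatter in this assay: the numbers show a 1.3-fold lower number from compound 2 to compound 3 (0.13 log units; within the scatter), and a 1.8-fold lower number from compound 1 to compound 3 (0.26 log units; within the scatter). On this phenyl ring, then, neither the 2-fluorophenyl nor the 3-fluorophenyl form is set apart from plain phenyl by a real difference. Nothing measured here offers an explanation for this result. Still open, going by these compounds, is whether a different group on this ring, such as an amine, a methoxy group or a carboxylic acid, would shift the number beyond the scatter.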